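The compounds below may be only part of what the source reports. "The series", "measured", "known", "first", "only" and "open" are said of these compounds alone.

Notes on the series. Compound 1 `CS(=O)(=O)Cc1cccc2c1CCC2c1ncc[nH]1` is the reference point of the set. For the measured compounds named here, in a functional assay on CHO cells for agonist activity at Alpha-1A adrenergic receptor (Homo sapiens), read by fluorescence and calcium flux (on this read-out lower numbers stand for smaller maximal responses and higher numbers for larger maximal responses), compound 1 gives 70%, the higher of the two numbers measured so far. Compound 2 `COCc1c(F)ccc2c1CC[C@H]2c1ncc[nH]1` differs from compound 1 in more than one place. In this assay compound 2 gives 59%; the gap between these two values lies beyond the usual scatter, so compound 1 stands above compound 2 on this read-out. Compound 3 `Fc1ccn(Cc2cccc3c2CCC3c2ncc[nH]2)n1` is not yet measured. Against compound 1 the difference is 3-fluoro-1H-pyrazol-1-yl in place of methylsulfonyl on a saturated chain carbon bound to an aromatic carbon. Going by the values given here, no pair of measured compounds differs in just this way, so the size of the step cannot be read from the data. An expected step of a number 8 percentage points lower from compound 1 to compound 3 (within the scatter) is assumed, a small shift downward that stays within the usual scatter. The estimate for compound 3 in this assay is 62%, with a range from 42% to 82%.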

Compound 3, largest response reached (Emax), in percent of the reference or control that the assay uses in the Alpha-1A adrenergic receptor assay: 83%
Estimate against measurement, compound 3: 21 percentage points below; the measured number lies above the stated range.
By their numbers in the Alpha-1A adrenergic receptor assay, from the lowest: compound 2; then compound 1; then compound 3.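

In the Alpha-1A adrenergic receptor assay, 3-fluoro-1H-pyrazol-1-yl in place of methylsulfonyl on a saturated chain carbon bound to an aromatic carbon gives a number 13 percentage points higher from compound 1 to compound 3 (beyond the scatter), so methylsulfonyl is not required for a high maximal response at this place. In a physicochemical assay for lipophilicity, at pH 7.4 (a lower number here means a more polar compound, a higher number a more lipophilic compound), compound 1 gives 0.7 and compound 3 gives 2.4. The higher maximal response therefore arrives together with a more lipophilic compound: the measured distribution coefficient of compound 1, 0.7, and of compound 3, 2.4, a number 1.70 log units higher (beyond the scatter)

A single pair cannot separate the contribution of the aromatic ring from that of lipophilicity, and the step from compound 1 to compound 2 cannot be read because they differ in more than one place. Going by these compounds, it also remains open whether an amine or a carboxylic acid on the same chain carbon would keep this maximal response.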